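Methoxy removal on the pendant aryl of compound 1

This account rests on a few compounds, and the source may have more. Where it says the series, first, only, none or still open, it means among the compounds named here.

Measured so far:
compound 1 `COc1ccc(-c2[nH]c3ccccc3c2/C=C(\C#N)S(=O)(=O)c2ccccc2)cc1`: 1100 nM
compound 2 `COc1ccc(-c2[nH]c3ccc(OC)cc3c2/C=C(\C#N)S(=O)(=O)c2ccccc2)cc1`: 1600 nM

In a functional assay on SF-268 cells (Homo sapiens) for inhibition, read by sulforhodamine B assay, with a stated time of 48 h (a higher number here means a weaker inhibitor of growth, a lower number a stronger inhibitor of growth), compound 1 gives 1100 nM, the lowest of the two numbers available, and compound 2 gives 1600 nM. Among the compounds with values here, the one step measured, a 1.5-fold higher number from compound 1 to compound 2 (0.16 log units; within the scatter), concerns a methoxy in place of hydrogen on an aromatic carbon of the shared core and does not rise above the scatter.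

Compound 3 `N#C/C(=C\c1c(-c2ccccc2)[nH]c2ccccc12)S(=O)(=O)c1ccccc1` is the next analogue. Relative to compound 1 the change is hydrogen in place of methoxy on an aromatic carbon; cut one bond further out, it reads 4-methoxyphenyl to phenyl. Within the data shown here, no measured pair shows exactly this change at this place. The only related information is the methoxy step on the core, which stayed within the scatter, so a methoxy elsewhere on the molecule is taken as a weak handle in this assay until shown otherwise.

On that basis compound 3 is expected to sit close to compound 1, with a step of a 1.2-fold higher number from compound 1 to compound 3 (0.07 log units; within the scatter) that need not exceed the scatter. The estimate for compound 3 is 1300 nM, with a range from 500 nM to 3500 nM.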

Compound 3, concentration for 50% growth inhibition: 4500 nM
For compound 3 the middle estimate is 3.5-fold (0.54 log units) below the measured one; measured number outside the range, above it.
By their numbers in this assay, from the lowest: compounds 1 and 2 (each within the scatter of the next); then compound 3.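

Going from 4-methoxyphenyl to phenyl gives a 4.1-fold higher number from compound 1 to compound 3 (0.61 log units; beyond the scatter) in this assay, which makes this place, on a six-membered aromatic ring of carbon only and para to a large group, the first in the series where a single change moves the number beyond the scatter. The methoxy on the shared core gave only a 1.5-fold higher number from compound 1 to compound 2 (0.16 log units; within the scatter) and stayed within the scatter, so the two methoxy places do not behave alike and a reading from one does not carry over to the other, although each rests on a single pair. No measurement available here bears on what lies behind the step.

Going by these compounds, it remains open whether the lower number of compound 1 belongs to methoxy specifically or would hold for other groups at this place, and a hydroxyl, an ethoxy, a chlorine or a dimethylamino group there would separate those readings. On these data alone, it also remains open whether moving the methoxy elsewhere on the pendant phenyl ring would keep the number of compound 1 or give that of compound 3.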